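This account rests on a few compounds, and the source may have more. Where it says the series, first, only, none or still open, it means among the compounds named here.

Measured so far:
compound 1 `COC(=O)/C=C/c1ccc2c(c1)C(=O)C(=O)N2Cc1ccc(C)cc1`, 50 nM
compound 2 `COC(=O)/C=C/c1ccc2c(c1)C(=O)C(=O)N2Cc1ccc(OC)cc1`, 30 nM

For the measured compounds named here, in a functional assay on Jurkat cells (Homo sapiens) for antiproliferative activity, read by MTT assay, with a stated time of 48 h (a lower number here means a stronger inhibitor, a higher number a weaker inhibitor), compound 2 gives 30 nM; compound 1, the only other number, gives 50 nM, and the step of a 1.7-fold lower number from compound 1 to compound 2 (0.22 log units; within the scatter) stays within the scatter, so the two compounds sit alongside each other. Compound 3 `CCCCOC(=O)/C=C/c1ccc2c(c1)C(=O)C(=O)N2Cc1ccc(OC)cc1` differs from compound 2 by propyl in place of hydrogen on a saturated chain carbon bound to an oxygen next to a carbonyl group. Going by the values given here, the single measured step, a 1.7-fold lower number from compound 1 to compound 2 (0.22 log units; within the scatter), concerns a different group and does not bear on this change; no measured step speaks to it. The expected outcome is therefore no step beyond the scatter, no change at the digits printed from compound 2 to compound 3 (within the scatter). Compound 3 is estimated at 30 nM, with a range from 10 nM to 100 nM.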

Compound 3, half-maximal inhibitory concentration: 220 nM
For compound 3 the middle estimate is 7.3-fold (0.87 log units) below the measured one; the measured number lies above the stated range.
By their numbers in this assay, from the lowest: compounds 2 and 1 (each within the scatter of the next); then compound 3.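

Going from methoxycarbonyl to butoxycarbonyl gives the first step beyond the scatter in the series: in this assay it reads a 7.3-fold higher number from compound 2 to compound 3 (0.87 log units; beyond the scatter). This position therefore responds to chain extension, unlike the aromatic change, where the step of a 1.7-fold lower number from compound 1 to compound 2 (0.22 log units; within the scatter) stayed within the scatter. Nothing at hand accounts for this result.

The compounds shown leave open whether the number rises gradually through ethoxycarbonyl and propoxycarbonyl or only at butoxycarbonyl. Going by these compounds, how a carboxylic acid or a longer chain such as hexyloxycarbonyl would read here also remains open.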